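Chloro for fluoro on the aryl amide of compound 1

The source may hold more compounds than are shown below. What is called first, only, known or untested is meant among the compounds shown, and "the series" means these compounds.

Three compounds in this series carry numbers in a functional assay on HEK293 cells for agonist activity at D(4) dopamine receptor (Homo sapiens), read by FLIPR; on this read-out lower numbers stand for smaller maximal responses and higher numbers for larger maximal responses. Compound 1 `Cc1cc(C(=O)NCN2CCC(c3cccc[n+]3[O-])CC2)ccc1F` gives 67%. Compound 2 `Cc1cccc(NC(=O)CN2CCC(c3cccc(O)c3)CC2)c1` gives 66%, and compound 3 `COc1cccc(C)c1NC(=O)CN1CCC(c2ccccn2)CC1` gives 69%. On these three numbers compound 1 stands second highest, with compound 2 nearest and compound 3 furthest, but both gaps fall within the scatter of repeated runs, so no order among the three can be read from them. Among the compounds with values here, no pair of measured compounds differing in one place is available, so no single-change step has been seen.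

Compound 4 `Cc1cc(C(=O)NCN2CCC(c3cccc[n+]3[O-])CC2)ccc1Cl` has not been measured. It differs from compound 1 in one place: chloro in place of fluoro on an aromatic carbon. The exchange sits on an aromatic carbon of a six-membered carbon-only ring, ortho to a methyl group and para to a large group; at one bond further out it reads 4-fluoro-3-methylphenyl to 4-chloro-3-methylphenyl. Nothing measured here shows this exchange, so the numbers give no direction for it.

With all three measured compounds sitting in one narrow band in this assay, the step from compound 1 to compound 4 is expected to stay inside the scatter, no change at the digits printed from compound 1 to compound 4 (within the scatter), with no clear direction. Compound 4 is therefore expected to give about 67%, in a range from 55% to 78%.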

Compound 4, largest response reached (reported as efficacy), in percent of the reference or control that the assay uses: 62%
The estimate for compound 4 lay 5 percentage points above the measured number; the range from low to high includes it.
By their numbers in this assay, from the lowest: compounds 4, 2, 1 and 3 (each within the scatter of the next).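

In this assay, chloro in place of fluoro on the aromatic carbon ortho to a methyl group and para to a large group gives a number 5 percentage points lower from compound 1 to compound 4 (within the scatter), the first single-change step available in this series. On this read-out the exchange from 4-fluoro-3-methylphenyl to 4-chloro-3-methylphenyl therefore does not separate the two compounds, so at this position the two halogens cannot be told apart and the step sets no direction for further changes here. No independent data bear on what lies behind this step, and the reading rests on this single pair of values.

On these data alone, one exchange between two halogens gives no trend, so it remains open how the same position would read with bromo, trifluoromethyl, nitrile, methoxy or plain hydrogen in place of the halogen. Also open, as far as these compounds go, is whether the methyl group in the same ring can give way to ethyl or methoxy without a step beyond the scatter, and whether the chloro for fluoro exchange reads the same on a core other than that of compound 1.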